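The source may hold more compounds than are shown below. What is called first, only, known or untested is meant among the compounds shown, and "the series" means these compounds.

Measured compounds in a functional assay on HeLa cells (Homo sapiens) for antiproliferative activity, read by MTT assay, with a stated time of 72 h; a lower number here means a stronger inhibitor, a higher number a weaker inhibitor:
- compound 1, `CC(=O)OCC(CCn1cc(C#Cc2ccc(Br)cc2)c(=O)n(C(=O)c2ccccc2)c1=O)COC(C)=O`: 47200 nM
- compound 2, `CCCCCc1ccc(C#Cc2cn(CCC(COC(C)=O)COC(C)=O)c(=O)n(C(=O)c3ccccc3)c2=O)cc1`: 79100 nM
- compound 3, `O=c1[nH]c(=O)n(CCC(CO)CO)cc1C#Cc1ccc(Br)cc1`: 67700 nM

Compound 1 and compound 2 share one core; compound 3 carries another. How the core of compound 3 differs from that of compound 1 is not broken down here. Within the first core the change is pentyl in place of bromo on an aromatic carbon, and it gave a 1.7-fold higher number from compound 1 to compound 2 (0.22 log units; within the scatter).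

Compound 4, `CCCCCc1ccc(C#Cc2cn(CCC(CO)CO)c(=O)[nH]c2=O)cc1`, is not yet measured. It differs from compound 3 by pentyl in place of bromo on an aromatic carbon, the same change as that from compound 1 to compound 2, at a place described in the same words. For the measured compounds named here, since the only measured instance of this change gave a 1.7-fold higher number from compound 1 to compound 2 (0.22 log units; within the scatter), a step of similar size is expected, a 1.5-fold higher number from compound 3 to compound 4 (0.17 log units; within the scatter). The estimate for compound 4 in this assay is therefore 100000 nM, with a plausible range of 45000 nM to 220000 nM.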

Compound 4, half-maximal inhibitory concentration: 48200 nM
Compound 4: the middle estimate sits 2.1-fold (0.32 log units) above what was measured, within the range that was stated.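

In this assay, pentyl in place of bromo on an aromatic carbon of the second core gave a 1.4-fold lower number from compound 3 to compound 4 (0.15 log units; within the scatter). Set beside the step on the first core, the two steps cannot be told apart: the same change on two cores in this assay, a 1.7-fold higher number (0.22 log units; within the scatter) from compound 1 to compound 2 and a 1.4-fold lower number (0.15 log units; within the scatter) from compound 3 to compound 4, 2.4-fold (0.37 log units) apart, within the scatter of two such steps The change therefore carries across these two cores with no difference that can be read, but as each step lies within the scatter, this shows only that the exchange moves the number little on both, not that the step reverses between cores or holds on any further core.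

Open, from the compounds shown here alone, is whether a longer chain such as decyl, or a shorter one such as ethyl, would move the number beyond the scatter at this place. Going by these compounds, an amine or a carboxylic acid there also remains open on either core.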